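Three Biaryl Acids, Untested Cytotoxicity, One Oxadiazole Newcomer

The compounds below may be only part of what the source reports. "The series", "measured", "known", "first", "only" and "open" are said of these compounds alone.

Measured compounds, all in an ADME assay on HepG2 cells (Homo sapiens) for cytotoxicity, read by CellTiter-Glo and resazurin assay, with a stated time of 72 h; on this read-out lower numbers stand for an effect already at smaller amounts and higher numbers for an effect only at larger amounts of compound:
- compound 1, `CC(C)N(Cc1cccc(OCCCCCC(=O)O)c1)C(=O)c1ccc(-c2cccc(N(C)C)c2)cc1`: > 26000 nM
- compound 2, `CC(C)N(Cc1cccc(OCCCCCC(=O)O)c1)C(=O)c1ccc(-c2ccncc2)cc1`: > 26000 nM
- compound 3, `CC(C)N(Cc1cccc(OCCCCCC(=O)O)c1)C(=O)c1ccc(-c2cccc(-c3ccccc3)c2)cc1`: > 26000 nM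

All three compounds share the same core and differ only in the group attached to the outer aromatic ring. Each of the values is a limit of the assay, not a measured number. For compound 2 the value in this assay is such a limit. The same holds for compound 1 and for compound 3, so the three values sit together at the limit, as the limit of > 26000 nM in this assay, at which 3 of the 3 values shown sit, records.

Compound 4, `Cc1nnc(-c2cccc(-c3ccc(C(=O)N(Cc4cccc(OCCCCCC(=O)O)c4)C(C)C)cc3)c2)o1`, has not yet been measured. It differs from compound 2 by 3-(5-methyl-1,3,4-oxadiazol-2-yl)phenyl in place of pyridin-4-yl on an aromatic carbon.

Going by the values given here, the steps that bear on this change are a step that the two limits leave unreadable from compound 1 to compound 2 and a step that the two limits leave unreadable from compound 2 to compound 3, together with a step that the two limits leave unreadable from compound 1 to compound 3. None of them can be read in size, since both ends of each step are limits. Among the compounds with values here, there is therefore no measured step that points in either direction, and nothing to suggest that compound 4 would behave differently from the three measured compounds.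

Compound 4 is expected to remain at the limit as well, with an estimated value of 30000 nM, ranging from 15000 nM to 60000 nM. The estimated step from compound 2 is a step that the limit leaves unreadable from compound 2 to compound 4.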

Compound 4, half-maximal effective concentration: > 26000 nM
Compound 4: no number, only a limit (the forecaster's own chance of this, stated with the estimate: 85%); the middle value does not contradict the limit.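

In this assay compound 4 also gives only a limit, as do compound 1, compound 2 and compound 3, so no step among these four compounds can be read in size: the limit of > 26000 nM in this assay, at which 4 of the 4 values shown sit.

Still open, going by these compounds, is at what amount each of the four compounds would show an effect, and whether swapping the outer group changes that amount.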